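The compounds below may be only part of what the source reports. "The series", "measured", "known", "first", "only" and "open" are said of these compounds alone.

Three compounds built on one shared core differ only in the aryl group attached to a carbon with a double bond to nitrogen. In a functional assay, with a stated time of 30 min (on this read-out higher numbers stand for weaker inhibition and lower numbers for stronger inhibition), compound 1 `CCCCc1oc2ccc(/N=C/c3ccc(C#N)cc3)cc2c1C(=O)c1ccc(OC)cc1` gives 27.2 ug/mL, compound 2 `CCCCc1oc2ccc(/N=C/c3cccc([N+](=O)[O-])c3)cc2c1C(=O)c1ccc(OC)cc1` gives 34.2 ug/mL, and compound 3 `CCCCc1oc2ccc(/N=C/c3ccc(OC)cc3OC)cc2c1C(=O)c1ccc(OC)cc1` gives 20.5 ug/mL, the lowest of the three numbers, although a 1.3-fold lower number from compound 1 to compound 3 (0.12 log units; within the scatter) and a 1.7-fold lower number from compound 2 to compound 3 (0.22 log units; within the scatter) both stay within the scatter, as does a 1.3-fold higher number from compound 1 to compound 2 (0.10 log units; within the scatter). Compound 4 `CCCCc1oc2ccc(/N=C/c3ccccc3)cc2c1C(=O)c1ccc(OC)cc1` carries phenyl in place of 2,4-dimethoxyphenyl on a carbon with a double bond to nitrogen. Every measured exchange of this aryl group left this assay essentially unchanged, so a 1.2-fold higher number from compound 3 to compound 4 (0.09 log units; within the scatter) is expected to be no larger than the scatter, in no particular direction. Compound 4 is therefore estimated at 25 ug/mL in this assay, within a range from 13 ug/mL to 50 ug/mL.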

Compound 4, half-maximal inhibitory concentration: 34.2 ug/mL
Compound 4: middle estimate off by 1.4-fold (0.14 log units), on the low side, within the range that was stated.
By their numbers in this assay, from the lowest: compounds 3, 1, 2 and 4 (each within the scatter of the next).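

In this assay the plain phenyl, which carries no substituent, stays within the scatter of all three substituted aryl groups (a 1.7-fold higher number from compound 3 to compound 4 (0.22 log units; within the scatter); no change at the digits printed from compound 2 to compound 4 (within the scatter); a 1.3-fold higher number from compound 1 to compound 4 (0.10 log units; within the scatter)). So none of the methoxy, nitro or cyano substituents is shown to be needed on this aryl group, which adds the unsubstituted ring to the flat picture. No supporting data bear on why this is so. Still open, on these data alone, is whether the picture holds with an amine or a carboxylic acid on the ring, or with a longer alkyl chain replacing the aryl group entirely.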